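A few compounds are considered here, and "the series" means these few. Any claim that something is new, unique, unknown or untested is made for them only; others in the source may bear on it.

Compound 1, `Clc1ccc2[nH]c(-c3nc(-c4ccccc4)no3)cc2c1`: in a functional assay on MIA PaCa-2 cells (Homo sapiens) for antiproliferative activity, read by WST assay, with a stated time of 72 h (on this read-out lower numbers stand for stronger inhibition and higher numbers for weaker inhibition), compound 1 gives 23100 nM.
Compound 2, `Clc1ccc(-c2noc(-c3cc4cc(Cl)ccc4[nH]3)n2)cc1`: for compound 2 this assay reports only a limit, > 50000 nM.
Compound 3, `COc1ccc(-c2noc(-c3cc4cc(OC)ccc4[nH]3)n2)cc1`: in this assay compound 3 gives 5600 nM.

Compound 3 stands lowest of the two numbers in this assay, with compound 1 as its nearest neighbour at a higher number, beyond the scatter. Compound 2 sits at the limit of > 50000 nM in this assay, at which 1 of the 3 values shown sits.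

Compound 4, `COc1ccc(-c2noc(-c3cc4cc(Cl)ccc4[nH]3)n2)cc1`, differs from compound 3 by chloro in place of methoxy on an aromatic carbon. Among the measured compounds shown here, no measured step makes exactly this exchange. For the measured compounds named here, the single measured step, an at least 2.1-fold higher number from compound 1 to compound 2 (0.33 log units; beyond the scatter), puts chloro in for hydrogen and weakened inhibition; compound 1 and compound 3 differ in two places, so their values can only be set side by side, and compound 4 shares the chloro of compound 1 and the methoxy-bearing phenyl of compound 3. In this assay compound 4 is therefore estimated to give about 11000 nM, with a range from 3500 nM to 35000 nM. That estimate means a 2.0-fold higher number from compound 3 to compound 4 (0.29 log units; within the scatter), a modest weakening expected because compound 1 carries the same chloro and gives 23100 nM.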

Compound 4, half-maximal inhibitory concentration: 7800 nM
Estimate against measurement, compound 4: 1.4-fold (0.15 log units) above; the range from low to high includes it.
By their numbers in this assay, from the lowest: compounds 3 and 4 (each within the scatter of the next); then compound 1. At a limit, above all of these: compound 2.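

At this position, on an aromatic carbon of a six-membered aromatic ring of carbon only, part of a fused or bridged system of two rings, chloro and methoxy cannot be told apart in this assay: the exchange gives a 1.4-fold higher number from compound 3 to compound 4 (0.14 log units; within the scatter). The second substituted place in the molecule behaves differently, since with that chloro kept, methoxy in place of hydrogen gives a 3.0-fold lower number from compound 1 to compound 4 (0.47 log units; beyond the scatter), so the earlier gap between compound 1 and compound 3 need not be credited to the position on the fused system. Methoxy in place of chloro at that second place gives an at least 6.4-fold lower number from compound 2 to compound 4 (0.80 log units; beyond the scatter), and the size of this step is only a bound, as the first compound of the pair stands at a limit and not at a number: the limit of > 50000 nM in this assay, at which 1 of the 4 values shown sits.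

The compounds shown leave open whether an amine or a carboxylic acid at the position on the fused system would also stay within the scatter of chloro and methoxy, and what plain hydrogen would give there alongside the methoxy at the second place. They also leave open whether a longer chain, such as ethoxy, at the second place would carry the gain from methoxy any further.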